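Swapping naphthalen-2-yl for benzyl on the amine nitrogen

A few compounds are considered here, and "the series" means these few. Any claim that something is new, unique, unknown or untested is made for them only; others in the source may bear on it.

In a functional assay on HEp-2 cells (Homo sapiens) for cytotoxicity, read by MTT assay, with a stated time of 24 h (on this read-out lower numbers stand for stronger inhibition and higher numbers for weaker inhibition), compound 1 `COc1cc(C)cc2c1C(=O)C=C(c1c(C)cc3c(c1OC)C(=O)C(Nc1ccc(Cl)cc1)=CC3=O)C2=O` gives 650 nM and compound 2 `COc1cc(C)cc2c1C(=O)C=C(c1c(C)cc3c(c1OC)C(=O)C(Nc1ccc4ccccc4c1)=CC3=O)C2=O` gives 2040 nM as the higher of the two numbers. Among the compounds with values here, compound 3 `COc1cc(C)cc2c1C(=O)C=C(c1c(C)cc3c(c1OC)C(=O)C(NCc1ccccc1)=CC3=O)C2=O` carries benzyl in place of naphthalen-2-yl on an amine nitrogen as its only change from compound 2. Within the data shown here, the one measured step at this nitrogen is modest: a 3.1-fold higher number from compound 1 to compound 2 (0.50 log units; beyond the scatter) when naphthalen-2-yl replaced 4-chlorophenyl. That single step is thin evidence, but it suggests that removing naphthalen-2-yl may lower the number. A smaller step in this assay is therefore expected: a 1.9-fold lower number from compound 2 to compound 3 (0.27 log units; within the scatter) as the estimate. For compound 3 the estimated value is 1100 nM with an expected range from 350 nM to 3500 nM in this read-out.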

Compound 3, half-maximal inhibitory concentration: 2610 nM
Compound 3: the middle estimate sits 2.4-fold (0.38 log units) below what was measured; measured number inside the range.
By their numbers in this assay, from the lowest: compound 1; then compounds 2 and 3 (each within the scatter of the next).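

In this assay, replacing naphthalen-2-yl with benzyl on the amine nitrogen gives no readable change (a 1.3-fold higher number from compound 2 to compound 3 (0.11 log units; within the scatter)), even though one aromatic ring of carbon takes the place of two. Compound 1 also has one such ring, yet 4-chlorophenyl and benzyl do differ (a 4.0-fold higher number from compound 1 to compound 3 (0.60 log units; beyond the scatter)), so among these three compounds the ring count alone does not set the number. Nothing available gives a reason for these numbers. Left open is what plain phenyl or a chlorobenzyl group would give on this nitrogen, which would help separate the effect of the chlorine from that of the carbon link to the ring.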